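The compounds below may be only part of what the source reports. "The series", "measured", "known", "first", "only" and "open" are said of these compounds alone.

Compound 1, `CC1(CN)CCN(c2c(F)cc3c(=O)c(C(=O)O)cn(C4CC4)c3c2F)C1`, gives 8 ug/mL in a functional assay on V79 cells (Cricetulus griseus) for cytotoxicity, read by colony formation; on this read-out lower numbers stand for stronger inhibition and higher numbers for weaker inhibition. Within the data shown here, compound 3, `CNCC1(C)CCN(c2c(F)cc3c(=O)c(C(=O)O)cn(C4CC4)c3c2F)C1`, carries the one change methyl in place of hydrogen on an amine nitrogen against compound 1, and in this assay compound 3 gives 8 ug/mL; the step of no change at the digits printed from compound 1 to compound 3 (within the scatter) thus left the read-out where it was. Compound 2, `CC1(CN)CCN(c2nc3c(cc2F)c(=O)c(C(=O)O)cn3C2CC2)C1`, is built on a different core; the difference between the two cores is not broken down here. In this assay compound 2 gives 25 ug/mL, the highest of the three numbers, sitting beyond the scatter from both compound 1 and compound 3.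

Compound 4, `CNCC1(C)CCN(c2nc3c(cc2F)c(=O)c(C(=O)O)cn3C2CC2)C1`, stands to compound 2 as compound 3 stands to compound 1: it carries the change (methyl in place of hydrogen on an amine nitrogen), set on an amine nitrogen whose other neighbour is a saturated chain carbon in both pairs, so it is the same change. The step from compound 2 to compound 4 is expected to be no change at the digits printed from compound 2 to compound 4 (within the scatter), which rests on the step of no change at the digits printed from compound 1 to compound 3 (within the scatter) having shown no change on the core of compound 1. Compound 4 is therefore estimated at 25 ug/mL in this assay, within a range from 12 ug/mL to 50 ug/mL.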

Compound 4, half-maximal inhibitory concentration: 58 ug/mL
The estimate for compound 4 lay 2.3-fold (0.37 log units) below the measured number; measured number above the stated range.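

In this assay, methyl in place of hydrogen on an amine nitrogen gives a 2.3-fold higher number from compound 2 to compound 4 (0.37 log units; beyond the scatter) and this counts as a modest step on the core of compound 2. Set beside the earlier step on the core of compound 1, this result does not separate the two cores, since the gap between the two steps lies within the scatter expected of such a pair: the same change on two cores in this assay, no change at the digits printed (within the scatter) from compound 1 to compound 3 and a 2.3-fold higher number (0.37 log units; beyond the scatter) from compound 2 to compound 4, 2.3-fold (0.37 log units) apart, within the scatter of two such steps. Among these compounds, the change may therefore have carried across with the same effect, but the data do not show that it did, nor do they show a true dependence on the core, and each core offers only a single matched pair.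

The compounds shown leave open how an ethyl group or a second methyl on this amine nitrogen would read in this assay. They also leave open whether the methyl step would hold on a third core, or on a pyrrolidine side chain without the methyl group on its ring.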